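A few compounds are considered here, and "the series" means these few. Any claim that something is new, unique, unknown or untested is made for them only; others in the source may bear on it.

Measured compounds:
- compound 1, `COc1cc2c(Oc3ccc(NC(=O)c4cc(-c5ccccc5)nc5ccccc45)cc3F)ccnc2cc1OCCCN1CCCCC1`, 15 nM
- compound 2, `COc1cc2c(Oc3ccc(NC(=O)c4cc(-c5cccc(Cl)c5)nc5ccccc45)cc3F)ccnc2cc1OCCCN1CCC(C)CC1`, 30 nM

In a functional assay on MKN-45 cells (Homo sapiens) for cytotoxicity, read by MTT assay, with a stated time of 72 h (on this read-out lower numbers stand for stronger inhibition and higher numbers for weaker inhibition), compound 1 gives 15 nM. In this assay compound 2 gives 30 nM, the higher of the two numbers shown, but the gap to compound 1 lies within the usual scatter of this assay, so the two compounds cannot be told apart on these data.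

The next compound, compound 3, `COc1cc2c(Oc3ccc(NC(=O)c4cc(-c5ccccc5)nc5ccccc45)cc3F)ccnc2cc1OCCCN1CCC(C)CC1`, has not yet been measured. It differs from compound 2 in one place: hydrogen in place of chloro on an aromatic carbon, meta to a large group; cut one bond further out, the difference reads 3-chlorophenyl to phenyl. Going by the values given here, no measured pair in this set shares that change, so its size can only be guessed from the two numbers at hand, which sit close together. The step of a 1.5-fold lower number from compound 2 to compound 3 (0.18 log units; within the scatter) is expected to be small, not beyond the scatter in either direction. Compound 3 is accordingly estimated at 20 nM, with a range from 8 nM to 50 nM.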

Compound 3, half-maximal inhibitory concentration: 19 nM
For compound 3 the middle estimate is 1.1-fold (0.02 log units) above the measured one; the measured number falls inside the stated range.
By their numbers in this assay, from the lowest: compounds 1, 3 and 2 (each within the scatter of the next).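

Going by these compounds alone, compound 3 differs in one place from each of the two earlier compounds, so it gives the first single-change comparisons in this set. Compounds 1 and 2 differ in two places and give no such comparison. In this assay, the change from 3-chlorophenyl to phenyl gives a 1.6-fold lower number from compound 2 to compound 3 (0.20 log units; within the scatter), while methyl in place of hydrogen on a saturated ring carbon gives a 1.3-fold higher number from compound 1 to compound 3 (0.10 log units; within the scatter), so on these data neither the chloro nor the methyl can be told apart from hydrogen at its position. No other measurement shown here bears on either step.

On these data alone, it remains open whether a fluoro, a methoxy or an amine on the same aromatic carbon would give a step beyond the scatter, and whether a hydroxyl or a carboxylic acid in place of the methyl on the saturated ring carbon would do so. Also open, as far as these compounds go, is whether either comparison would hold with other groups elsewhere on the shared core, since each change is seen only once here.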